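Replacing the Sulfonamide Arm in a Weak Antiproliferative Series

This account rests on a few compounds, and the source may have more. Where it says the series, first, only, none or still open, it means among the compounds named here.

Measured compounds:
- compound 1 `N#CC1=C(N)Oc2c(c3nc4ccccc4nc3c3ccccc23)C12C(=O)N(Cc1cnnn1-c1ccc(S(N)(=O)=O)cc1)c1ccccc12`: > 50000 nM in an ADME assay on HUVEC cells (Homo sapiens) for antiproliferative activity, read by MTT assay, with a stated time of 48 h; a lower number here means a stronger inhibitor, a higher number a weaker inhibitor
- compound 2 `N#CC1=C(N)Oc2c(c3nc4ccccc4nc3c3ccccc23)C12C(=O)N(Cc1cnnn1-c1cccc(S(N)(=O)=O)c1)c1ccccc12`: 38600 nM in this assay

Compound 1 gives only a limit of this assay, (the limit of > 50000 nM in this assay, at which 1 of the 2 values shown sits). For the measured compounds named here, compound 2 is therefore the only compound with a number, and that number is a weak one. Going by the values given here, the one measured step, an at least 1.2-fold lower number from compound 1 to compound 2 (0.11 log units; that floor lies within the scatter), changes only where the sulfamoyl group sits on the phenyl ring, and its size is within the scatter.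

Compound 3 `Cc1cc(C)cc(-n2nncc2CN2C(=O)C3(C(C#N)=C(N)Oc4c3c3nc5ccccc5nc3c3ccccc43)c3ccccc32)c1` differs from compound 2 in a different way: 3,5-dimethylphenyl in place of 3-sulfamoylphenyl on an aromatic nitrogen. Among the compounds with values here, no measured step removes the sulfamoyl group altogether, so the step from compound 1 to compound 2 bears on this change only loosely, by showing that shifting the sulfamoyl group gave nothing beyond the scatter. With both measured compounds weak, the expectation for compound 3 is a number close to that of compound 2, with a fair chance that the assay again reports only a limit. Compound 3 is estimated at 35000 nM, expected between 9000 nM and 140000 nM, which means an expected step of a 1.1-fold lower number from compound 2 to compound 3 (0.04 log units; within the scatter).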

Compound 3, half-maximal inhibitory concentration: > 50000 nM
Compound 3: only a limit was reported; the forecaster's own chance of this, stated with the estimate: 40%; middle value at least 1.4-fold (0.15 log units) from the limit.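

In this assay compound 3 gives > 50000 nM, which is a limit of the assay and not a number. For the compounds shown here, replacing 3-sulfamoylphenyl with 3,5-dimethylphenyl, an all-carbon group with no hydrogen-bond donors or acceptors, removes the sulfamoyl group from this aromatic nitrogen for the first time and gives an at least 1.2-fold higher number from compound 2 to compound 3 (0.11 log units; that floor lies within the scatter), so this change brings no measurable gain, and the printed floor is too small to show a real loss. The step from compound 1 to compound 3 cannot be read, and compound 2 remains the only compound with an actual number, while the others sit at the top of the range the assay reports: the limit of > 50000 nM in this assay, at which 2 of the 3 values shown sit.

Going by these compounds, what stays open is whether any group on this aromatic nitrogen can bring the number clearly down, for example a phenyl ring carrying an amine or a carboxylic acid, or a longer chain in place of the ring. Also open, on these data alone, is how far compound 1 and compound 3 actually lie from compound 2, since a limit does not give that distance, and whether changes elsewhere on the shared core would matter more than changes at this position.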